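From methoxy to hydrogen on compound 1

The source may report more compounds than this note shows. Statements on the series, on what has been measured and on what is new or still open speak of the compounds shown alone.

Compound 1 `COc1ccc(-c2nc3sc(-c4ccccc4)cn3n2)cc1`: 21%
Compound 2 `COc1cc(-c2nc(N)n(CC(=O)Nc3ccc(/C(C)=N\O)cc3)n2)cc(OC)c1OC`: 5.69%

In a functional assay on RPMI-8226 cells (Homo sapiens) for inhibition, read by sulforhodamine B assay, with a stated time of 48 h, tested at 10 uM (on this read-out higher numbers stand for more inhibition of growth at the one concentration tested and lower numbers for less inhibition of growth), compound 1 gives 21% and stands highest of the two measured compounds. Compound 2 at 5.69% lies lower, beyond the scatter. Compound 3 `c1ccc(-c2nc3sc(-c4ccccc4)cn3n2)cc1` has hydrogen in place of methoxy on an aromatic carbon para to a large group. For the measured compounds named here, no measured pair shows this change, so only a small fall is expected in this assay and none beyond the scatter. The estimate is a step (a number 5 percentage points lower from compound 1 to compound 3 (within the scatter)) of that small size. For compound 3 the estimated value is 16% (expected range 4% to 30%).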

Compound 3, percent growth inhibition at one concentration: 14%
Beside the measured number, compound 3's estimate is 2 percentage points above it, within the range that was stated.
By their numbers in this assay, from the lowest: compounds 2, 3 and 1 (each within the scatter of the next, the first and the last beyond it).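

For the compounds shown here, the step of a number 7 percentage points lower from compound 1 to compound 3 (within the scatter) is the first reading of this change in this assay and shows that, on this aromatic carbon para to a large group, hydrogen can stand in place of methoxy with no shift beyond the scatter. The shown data hold nothing that would explain this result. From the compounds shown here alone, whether an amine, a hydroxyl or a longer chain such as ethoxy at this position would read differently stays open, and so does whether the same change would behave alike on another core.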